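The source may report more compounds than this note shows. Statements on the series, on what has been measured and on what is new or still open speak of the compounds shown alone.

Measured compounds in a physicochemical assay for lipophilicity, measured as octanol-water partition; a higher number here means a more lipophilic compound, a lower number a more polar compound:
compound 1 `COc1ccc(/C=N/NC(=O)COc2cccc3ccccc23)cc1OC`, 3.51
compound 2 `Cc1ccc(/C=N/NC(=O)COc2cccc3ccccc23)cc1`, 4.49
compound 3 `C/C(=N\NC(=O)COc1cccc2ccccc12)c1ccccc1`, 3.65

Among these three, compound 2 stands highest in this assay. Compound 3 is nearest to it, yet the gap between them lies beyond the scatter, and compound 1 is furthest, again beyond the scatter. Compounds 1 and 3 themselves sit within the scatter of each other.

Compound 4 `O=C(COc1cccc2ccccc12)N/N=C/c1cccc(Cl)c1` has not yet been measured. It differs from compound 2 in one place: 3-chlorophenyl in place of 4-methylphenyl on a carbon with a double bond to nitrogen. With 3-chlorophenyl in place of 4-methylphenyl, a step of no more than the usual scatter is expected, if anything a slight rise, so the expected step is a number 0.11 log units higher from compound 2 to compound 4 (within the scatter). On that basis compound 4 is estimated at 4.6, with a range from 4.2 to 5.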

Compound 4, partition coefficient: 4.54
Compound 4: middle estimate off by 0.06 log units, on the high side; the range from low to high includes it.
By their numbers in this assay, from the lowest: compounds 1 and 3 (each within the scatter of the next); then compounds 2 and 4 (each within the scatter of the next).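

In this assay, within the data shown here, 3-chlorophenyl in place of 4-methylphenyl on a carbon with a double bond to nitrogen gives a number 0.05 log units higher from compound 2 to compound 4 (within the scatter), the first comparison here of compounds that differ in one place. At this position, then, the two groups cannot be told apart by this read-out. No measurement shown accounts for this.

The change alters both the substituent and its ring position, and these compounds cannot separate the two. As far as these compounds go, how an amine or a carboxylic acid on this ring would read remains open.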